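The source may report more compounds than this note shows. Statements on the series, on what has been measured and on what is new or still open speak of the compounds shown alone.

In a functional assay on HepG2 cells (Homo sapiens) for inhibition, read by MTT assay, with a stated time of 72 h (on this read-out higher numbers stand for weaker inhibition and lower numbers for stronger inhibition), compound 1 `Nc1ncnc2c1c(-c1cnc3[nH]ccc3c1)nn2CC(=O)NO` gives only a limit (> 150000 nM). Among the measured compounds shown here, compound 2 `Nc1nc2cc(-c3nn(CCCCCCCCCC(=O)NO)c4ncnc(N)c34)ccc2o1` holds the only actual number in this assay (28600 nM). Compound 3 `CNC(=O)CCCCCCCn1nc(-c2ccc3oc(N)nc3c2)c2c(N)ncnc21` differs from compound 2 by methylcarbamoyl in place of 2-(hydroxycarbamoyl)ethyl on a saturated chain carbon, seven bonds along the chain from an aromatic nitrogen. For the measured compounds named here, no measured step covers this change, so the expectation is tentative: a modest weakening in this assay, not far beyond the scatter. The expected step is a 2.1-fold higher number from compound 2 to compound 3 (0.32 log units; beyond the scatter). For compound 3 the estimated value is 60000 nM (expected range 22000 nM to 150000 nM).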

Compound 3, half-maximal inhibitory concentration: 3640 nM
Compound 3: middle estimate off by 16-fold (1.22 log units), on the high side; the measured number lies below the stated range.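

In this assay methylcarbamoyl in place of 2-(hydroxycarbamoyl)ethyl gives a 7.9-fold lower number from compound 2 to compound 3 (0.90 log units; beyond the scatter) and thus stronger inhibition. Within this pair, the hydroxycarbamoyl end is therefore not required for activity on this read-out, and this is the first measured step at this position. Nothing at hand accounts for the step. The step changes both the chain length and the terminal group, and these remain unseparated. A carboxylic acid or a primary amide on the same chain, or a longer chain ending in methylcarbamoyl, would help to separate them.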